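Fluoro in place of chloro in a cytotoxicity series

The source may hold more compounds than are shown below. What is called first, only, known or untested is meant among the compounds shown, and "the series" means these compounds.

Compound 3 `COc1cc(OC)c(C(=O)/C=C/c2ccc(Cl)cc2)c(OC)c1` gives 6000 nM in a functional assay on NCI-H727 cells (Homo sapiens) for cytotoxicity, with a stated time of 48 h (on this read-out lower numbers stand for stronger inhibition and higher numbers for weaker inhibition), and sits within the scatter of compound 2 `COc1cccc(/C=C/C(=O)c2c(OC)cc(OC)cc2OC)c1` at 8200 nM on the same read-out. Compound 1 `COc1cc(O)c(C(=O)/C=C/c2ccc(F)cc2)c(OC)c1` returns > 20000 nM as a limit of the assay. Compound 4 `COc1cc(OC)c(C(=O)/C=C/c2ccc(F)cc2)c(OC)c1` differs from compound 3 by fluoro in place of chloro on an aromatic carbon with fluoro in place of chloro on an aromatic carbon. Among the compounds with values here, the only measured step in that part of the structure is a 1.4-fold lower number from compound 2 to compound 3 (0.14 log units; within the scatter) and it offers no sign of a large effect there. No change beyond the scatter is therefore expected in this assay for this exchange. The estimated step is a 1.3-fold higher number from compound 3 to compound 4 (0.12 log units; within the scatter) and nothing larger is expected. Compound 4 is expected at 8000 nM with an estimated range from 3500 nM to 19000 nM in this read-out.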

Compound 4, half-maximal inhibitory concentration: 5500 nM
Compound 4: the middle estimate sits 1.5-fold (0.16 log units) above what was measured; low and high end bracket the measured number.
By their numbers in this assay, from the lowest: compounds 4, 3 and 2 (each within the scatter of the next). At a limit, above all of these: compound 1.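

In this assay the exchange of chloro for fluoro on this aromatic carbon gives a 1.1-fold lower number from compound 3 to compound 4 (0.04 log units; within the scatter) and so does not separate the two halogens, while a 1.5-fold lower number from compound 2 to compound 4 (0.17 log units; within the scatter) shows the 4-fluorophenyl group reading like the 3-methoxyphenyl group. Methyl in place of hydrogen on the oxygen on the aromatic ring is the only change shown to pass the scatter, with an at least 3.6-fold lower number from compound 1 to compound 4 (0.56 log units; beyond the scatter). That step has no upper end, as it rests on a limit: the limit of > 20000 nM in this assay, at which 1 of the 4 values shown sits. As far as these compounds go, whether an amine or a carboxylic acid in place of the halogen would move the number stays open, as does a longer chain on that oxygen.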